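Methyl on the pyridyl ether: a step without a direct precedent

The source may report more compounds than this note shows. Statements on the series, on what has been measured and on what is new or still open speak of the compounds shown alone.

Measured compounds:
- compound 1 `C#Cc1ccnc(O[C@@H]2CC[C@@H](C)N(C(=O)c3ccccc3-n3nccn3)C2)c1`: 240 nM
- compound 2 `COC(=O)c1ccnc(O[C@@H]2CC[C@@H](C)N(C(=O)c3ccccc3-n3nccn3)C2)c1`: 1800 nM
- compound 3 `C[C@@H]1CC[C@@H](Oc2ccccn2)CN1C(=O)c1ccccc1-n1nccn1`: "not determined" (no result reported)

All three share the same amide-linked core; only the aryl ether varies. Among the compounds with values here, in a functional assay on CHO-K1 cells for antagonist activity at Orexin/Hypocretin receptor type 1 (Homo sapiens), read by FLIPR and calcium flux (on this read-out lower numbers stand for stronger inhibition and higher numbers for weaker inhibition), compound 1 gives 240 nM and compound 2 gives 1800 nM; the step of a 7.5-fold higher number from compound 1 to compound 2 (0.88 log units; beyond the scatter) is the only measured change, and it concerns a group on a different aromatic carbon of the pyridyl ring. Compound 3, the unsubstituted pyridin-2-yl ether, stands without a number in this assay, so no anchor exists for it.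

Compound 4 `Cc1cccc(O[C@@H]2CC[C@@H](C)N(C(=O)c3ccccc3-n3nccn3)C2)n1` differs from compound 3 by methyl in place of hydrogen on an aromatic carbon. Within the data shown here, no measured step involves this position, and the one recorded step cannot be carried over to it. The expectation for compound 4 therefore rests only on the values of compound 1 and compound 2, which bracket where this series has landed so far; a value in the same region is expected. Compound 4 is estimated at 350 nM in this assay, with a wide range of 60 nM to 2000 nM.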

Compound 4, half-maximal inhibitory concentration: 745 nM
Estimate against measurement, compound 4: 2.1-fold (0.33 log units) below; low and high end bracket the measured number.
By their numbers in this assay, from the lowest: compound 1; then compound 4; then compound 2.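

In this assay, within the data shown here, a methyl next to the ring nitrogen leaves measurable activity, and compound 4 gives (745 nM) as the only number for a substituent at this place. Among the three ethers with numbers, 6-methylpyridin-2-yl falls between the other two, with both steps beyond the scatter (a 2.4-fold lower number from compound 2 to compound 4 (0.38 log units; beyond the scatter); a 3.1-fold higher number from compound 1 to compound 4 (0.49 log units; beyond the scatter)), ahead of 4-(methoxycarbonyl)pyridin-2-yl and behind 4-ethynylpyridin-2-yl. No evidence at hand accounts for these differences.

As far as these compounds go, the step from compound 3 to compound 4 cannot be read, as compound 3 has no result, so what methyl adds over hydrogen remains open. Also open, from the compounds shown here alone, is how ethyl, methoxy or an amine would fare at the same place, and whether methyl there combines with ethynyl on the same ring.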